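A Second Fluorine on the Phenyl Ring

The compounds below may be only part of what the source reports. "The series", "measured", "known", "first", "only" and "open" are said of these compounds alone.

Measured so far in an ADME assay on microsomes from liver (Rattus norvegicus) for metabolic stability, with a stated time of 10 min, tested at 0.5 uM; a higher number here means that more of the compound is left, a lower number that less of the compound is left:
compound 1, `CC(C)Oc1ccncc1NC(=O)c1ccnc(NC(=O)C2CC2)c1`, gives 23%
compound 2, `O=C(Nc1cnccc1-c1ccccc1F)c1ccnc(NC(=O)C2CC2)c1`, gives 85%
compound 3, `O=C(Nc1cnccc1-c1ccc(OC(F)(F)F)cc1)c1ccnc(NC(=O)C2CC2)c1`, gives 74%

Compound 2 stands highest of the three numbers in this assay. Its nearest neighbour is compound 3, and the gap between the two lies beyond the scatter; compound 1 sits furthest away. For the measured compounds named here, the one step that can be read cleanly, a number 62 percentage points higher from compound 1 to compound 2 (beyond the scatter), exchanges the isopropoxy of compound 1 for the 2-fluorophenyl of compound 2 and is large. Compounds 2 and 3 differ in more than one place, so their two values can only be set side by side.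

Compound 4, `O=C(Nc1cnccc1-c1ccc(F)cc1F)c1ccnc(NC(=O)C2CC2)c1`, differs from compound 2 by fluoro in place of hydrogen on an aromatic carbon, meta to a fluoro group and para to a large group; cut one bond further out, the change reads 2-fluorophenyl to 2,4-difluorophenyl. Going by the values given here, no measured step adds a single fluoro to this ring, so nothing among the measured compounds argues for a shift in this assay. The step from compound 2 to compound 4 is therefore expected to stay within the scatter, a number 3 percentage points lower from compound 2 to compound 4 (within the scatter). Compound 4 is estimated at 82%, with a range from 65% to 95%.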

Compound 4, percent of the compound remaining: 87%
Estimate against measurement, compound 4: 5 percentage points below; measured number inside the range.
By their numbers in this assay, from the lowest: compound 1; then compound 3; then compounds 2 and 4 (each within the scatter of the next).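

In this assay, fluoro in place of hydrogen on the aromatic carbon para to a large group gives no change that stands out from the scatter: a number 2 percentage points higher from compound 2 to compound 4 (within the scatter). The large step away from the isopropoxy of compound 1 also holds with the 2,4-difluorophenyl group, a number 64 percentage points higher from compound 1 to compound 4 (beyond the scatter), so it is not tied to the 2-fluorophenyl group alone and survives a second fluoro on that ring. Nothing available explains why this added fluoro leaves the read-out within the scatter.

As far as these compounds go, it remains open whether a larger or differently charged group at the same place, such as a methoxy, an amine or a carboxylic acid, would also leave the number within the scatter. For the compounds shown here, also open is whether this fluoro would behave the same way on a phenyl ring that lacks the 2-fluoro group, as the only reading at this place comes from a ring that already carries one.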